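Ester chain length and cell cytotoxicity, compounds 1 to 4

The compounds below may be only part of what the source reports. "The series", "measured", "known", "first", "only" and "open" are said of these compounds alone.

Measured so far in a functional assay on A549 cells (Homo sapiens) for cytotoxicity, read by MTT assay, with a stated time of 24 h, tested at 80 uM; a lower number here means a stronger effect, a higher number a weaker effect of the compound at the concentration tested:
compound 1, `CCCCCCCCCCCOC(=O)CCC(=O)N1CCN(CCCOc2cc3c(Nc4ccc(F)c(Cl)c4)ncnc3cc2OC)CC1`: 2.8%
compound 2, `CCCCCCCCCCCCCOC(=O)CCC(=O)N1CCN(CCCOc2cc3c(Nc4ccc(F)c(Cl)c4)ncnc3cc2OC)CC1`: 6.8%
compound 3, `CCCCCCCCCCCCCCCCCCOC(=O)CCC(=O)N1CCN(CCCOc2cc3c(Nc4ccc(F)c(Cl)c4)ncnc3cc2OC)CC1`: 86.7%

Compound 3 stands highest of the three numbers in this assay, and both of its steps from the other two lie beyond the scatter: a number 83.9 percentage points higher from compound 1 to compound 3 (beyond the scatter) and a number 79.9 percentage points higher from compound 2 to compound 3 (beyond the scatter). Compound 4, `CCCCCCCCCCCCCCCCCCCCOC(=O)CCC(=O)N1CCN(CCCOc2cc3c(Nc4ccc(F)c(Cl)c4)ncnc3cc2OC)CC1`, is not yet measured; it differs from compound 3 in one place, (ethyl in place of hydrogen on a saturated chain carbon, ten or more bonds along the chain from an oxygen next to a carbonyl group).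

Two kinds of measured step bear on this. The same change, an ethyl entering on the chain, has been seen once, as a number 4 percentage points higher from compound 1 to compound 2 (within the scatter), a step within the scatter. For the measured compounds named here, the larger chain extensions that lead to compound 3 are the only steps beyond the scatter, and both raise the number. Nothing shows whether the number can rise further past compound 3 or whether it has levelled off, so a small step at most is expected here, a number 1.3 percentage points higher from compound 3 to compound 4 (within the scatter). Compound 4 is therefore estimated at 88%, within a range from 72% to 100%.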

Compound 4, a percentage reported as activity, at one concentration (the size of the read-out at that concentration, not a potency): 85.2%
For compound 4 the middle estimate is 2.8 percentage points above the measured one; low and high end bracket the measured number.
By their numbers in this assay, from the lowest: compounds 1 and 2 (each within the scatter of the next); then compounds 4 and 3 (each within the scatter of the next).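

In this assay, ethyl in place of hydrogen on a saturated chain carbon, ten or more bonds along the chain from an oxygen next to a carbonyl group, now gives a second step within the scatter, a number 1.5 percentage points lower from compound 3 to compound 4 (within the scatter), so this change has twice produced no step beyond the scatter, at both the low and the high end of the read-out: the same change on two cores in this assay, a number 4 percentage points higher (within the scatter) from compound 1 to compound 2 and a number 1.5 percentage points lower (within the scatter) from compound 3 to compound 4, 5.5 percentage points apart, within the scatter of two such steps. The large gap seen earlier also holds for the newly measured chain, with a number 78.4 percentage points higher from compound 2 to compound 4 (beyond the scatter) and a number 82.4 percentage points higher from compound 1 to compound 4 (beyond the scatter). The series thus falls into two groups, with no listed compound against this split, and the heptyl steps on the two pairs are alike in size: the same change on two cores in this assay, a number 83.9 percentage points higher (beyond the scatter) from compound 1 to compound 3 and a number 78.4 percentage points higher (beyond the scatter) from compound 2 to compound 4, 5.5 percentage points apart, within the scatter of two such steps.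

Still open, from the compounds shown here alone, is where along the chain, between the lengths in compound 2 and compound 3, the number rises. Also open, going by these compounds, is whether a longer chain would stay level with compound 3 and compound 4.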